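Furan-3-yl to thiophen-2-yl: working notes on compound 3

The source may report more compounds than this note shows. Statements on the series, on what has been measured and on what is new or still open speak of the compounds shown alone.

Only limits are available so far for this series. In a functional assay on HeLa S3 cells (Homo sapiens) for antiproliferative activity, read by XTT assay, with a stated time of 72 h (a lower number here means a stronger inhibitor, a higher number a weaker inhibitor), compound 2 `Cc1ncnc2c1c(-c1ccoc1)cn2[C@@H]1O[C@H](CO)[C@@H](O)[C@H]1O` gives > 20000 nM as a limit of the assay and not as a number. In this assay compound 1 `CNc1ncnc2c1c(-c1cccs1)cn2[C@@H]1O[C@H](CO)[C@@H](O)[C@H]1O` gives > 20000 nM as a limit as well. Compound 2 therefore stands at the limit of > 20000 nM in this assay, at which 2 of the 2 values shown sit, and has no measured number to be ranked against.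

The next compound is compound 3 `Cc1ncnc2c1c(-c1cccs1)cn2[C@@H]1O[C@H](CO)[C@@H](O)[C@H]1O`, with thiophen-2-yl in place of furan-3-yl on an aromatic carbon of the shared core. Going by the values given here, no measured step is available to size this change. Among the compounds with values here, the expectation rests on compound 2 and its limit of > 20000 nM in this assay as the only anchor for the swap. The estimated step is an at least 1.3-fold lower number from compound 2 to compound 3 (0.12 log units; that floor lies within the scatter) and is expected to stay within the usual scatter, with no clear direction. For compound 3 an estimated 15000 nM is expected, with a range of 4000 nM to 40000 nM and another reading at the limit quite possible.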

Compound 3, half-maximal inhibitory concentration: > 15000 nM
Compound 3 gave a limit, no number (the forecaster's own chance of this, stated with the estimate: 60%); the middle value sits exactly at the limit.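

Compound 3 gives > 15000 nM in this assay, a limit and not a number. With compound 1, compound 2 and compound 3 all standing as limits, the steps from compound 2 and from compound 1 to compound 3 cannot be read. The compounds shown leave open whether thiophen-2-yl in place of furan-3-yl, or methyl in place of methylamino, shifts the value in this assay at all.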